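Replacing the hydroxycyclohexyl amine with an oxanylethyl chain

The source may hold more compounds than are shown below. What is called first, only, known or untested is meant among the compounds shown, and "the series" means these compounds.

Compound 3 `N#Cc1cnc(NCc2cnccc2C(F)(F)F)cc1N[C@H]1CC[C@H](O)CC1` gives 6500 nM in an assay on isolated protein for inhibition of protein kinase C delta type (Homo sapiens), read by TR-FRET, with a stated time of 2 h (a lower number here means a stronger inhibitor, a higher number a weaker inhibitor), the highest of the three numbers recorded there, though both neighbours sit within the scatter of it: compound 2 `N#Cc1cnc(NCc2cnccc2C(F)(F)F)cc1N[C@H]1CC[C@@H](O)CC1` gives 4500 nM and compound 1 `N#Cc1cnc(NCc2cnccc2C(F)(F)F)cc1NC[C@H]1C[C@@H](O)C1` gives 4200 nM. The steps of a 1.1-fold higher number from compound 1 to compound 2 (0.03 log units; within the scatter) and a 1.5-fold higher number from compound 1 to compound 3 (0.19 log units; within the scatter) changed the group on the ring nitrogen without moving the number beyond the scatter, and a 1.4-fold higher number from compound 2 to compound 3 (0.16 log units; within the scatter) also stayed inside it, in keeping with the fact that compounds 2 and 3 differ only in the configuration as drawn. Compound 4 `N#Cc1cnc(NCc2cnccc2C(F)(F)F)cc1NCCC1CCOCC1` carries 2-(oxan-4-yl)ethyl in place of 4-hydroxycyclohexyl on a nitrogen on an aromatic ring. Since every earlier change at this nitrogen left the number within the scatter, compound 4 is expected to show a 1.1-fold lower number from compound 3 to compound 4 (0.03 log units; within the scatter), no step beyond the scatter. Compound 4 is therefore estimated at 6000 nM, with a range from 2000 nM to 18000 nM.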

Compound 4, half-maximal inhibitory concentration: > 10000 nM
Compound 4 was reported as a limit (the forecaster's own chance of this, stated with the estimate: 15%); middle value at least 1.6-fold (0.22 log units) away from the limit.
By their numbers in this assay, from the lowest: compounds 1, 2 and 3 (each within the scatter of the next). At a limit, above all of these: compound 4.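

In this assay compound 4 gives > 10000 nM, which is a limit and not a number. Within the data shown here, it brings the first steps at this nitrogen that lie beyond the scatter, an at least 2.2-fold higher number from compound 2 to compound 4 (0.34 log units; beyond the scatter) and an at least 2.3-fold higher number from compound 1 to compound 4 (0.37 log units; beyond the scatter), so this position does not accept every change. As far as these compounds go, the third step, an at least 1.5-fold higher number from compound 3 to compound 4 (0.18 log units; that floor lies within the scatter), has a floor within the scatter, so its true size remains unknown. The compounds shown leave open whether the oxane ring or the ethyl link matters more, as the change replaces both the hydroxycyclohexyl ring and the direct attachment. A 2-(4-hydroxycyclohexyl)ethyl group would separate the two.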